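The source may report more compounds than this note shows. Statements on the series, on what has been measured and on what is new or still open speak of the compounds shown alone.

Of the compounds shown here, three so far have numbers in an ADME assay on L6 cells (Rattus norvegicus) for cytotoxicity, read by fluorescence and resazurin assay, with a stated time of 72 h; on this read-out lower numbers stand for higher toxicity in this test and higher numbers for lower toxicity in this test. Compound 1 (`COc1ccc(-c2c[nH]cc2C(c2ccc(Cl)cc2Cl)n2ccnc2)cc1`) gives 14800 nM and compound 2 (`Clc1ccc(C(c2c[nH]cc2-c2ccc(Cl)cc2-c2ccccc2)n2ccnc2)cc1`) gives 14900 nM, two values within the usual scatter of each other. Compound 3 (`O=[N+]([O-])c1ccc(-n2ccc(C(c3ccccc3)n3ccnc3)c2)cc1`) gives 60400 nM, the highest of the three numbers and beyond the scatter from both of the others. No two of these compounds differ in one place only, so the series offers no measured step to carry over.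

Compound 4 (`O=[N+]([O-])c1ccc(C(c2ccn(-c3ccc([N+](=O)[O-])cc3)c2)n2ccnc2)cc1`) is still to be measured in this assay. It differs from compound 3 by a single change: nitro in place of hydrogen on an aromatic carbon. This is nitro in place of hydrogen on an aromatic carbon, phenyl to 4-nitrophenyl.

With compound 3 at 60400 nM standing at the top of the three numbers, a move downward is judged more likely than a move upward, though this rests on very few data. The expected shift is modest, towards higher toxicity in this test and close to the edge of the scatter, with an estimated 2.0-fold lower number from compound 3 to compound 4 (0.30 log units; within the scatter). The estimate for compound 4 is 30000 nM, with an expected range of 11000 nM to 70000 nM.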

Compound 4, half-maximal cytotoxic concentration: 159000 nM
For compound 4 the middle estimate is 5.3-fold (0.72 log units) below the measured one, outside the stated range (above it).
By their numbers in this assay, from the lowest: compounds 1 and 2 (each within the scatter of the next); then compound 3; then compound 4.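

In this assay, among these compounds, nitro in place of hydrogen on an aromatic carbon of a six-membered aromatic ring of carbon only, para to a large group, gives a 2.6-fold higher number from compound 3 to compound 4 (0.42 log units; beyond the scatter) and is the first measured step that changes one place only. The change from phenyl to 4-nitrophenyl therefore goes with a number beyond the scatter towards lower toxicity in this test, and compound 4 at 159000 nM now stands highest of the four, so this position accepts the added nitro with no rise in toxicity in this test. Nothing measured here bears on what lies behind this direction.

This single pair cannot separate an effect specific to nitro from one shared by other groups at this position, and an amine or a carboxylic acid in the same place would test that distinction. Going by these compounds, it also remains open whether nitro at this position gives a step of similar direction and size on other members, since this step comes from one pair alone.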